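The compounds below may be only part of what the source reports. "The series", "measured", "known", "first", "only" and "open" are said of these compounds alone.

Measured so far in an assay on isolated protein for inhibition of aldehyde dehydrogenase 1A1 (Homo sapiens), read by spectrophotometry, tested at 10 uM; on this read-out lower numbers stand for less inhibition and higher numbers for more inhibition at the one concentration tested (going by the name of the read-out):
Compound 1, `CCc1ccc(C(=O)N2CCN(Cc3nc4ccccc4n3Cc3cccc(C)c3)CC2)cc1`, gives 67%.
Compound 2, `CC(=O)N1CCN(Cc2nc3ccccc3n2Cc2cccc(C)c2)CC1`, gives 70.3%.
Compound 3, `Cc1cccc(Cn2c(CN3CCN(C(=O)c4cccs4)CC3)nc3ccccc32)c1`, gives 60.8%.

Compound 3 holds the lowest of the three numbers, but its nearest neighbour on the scale is compound 1, and the step from compound 1 to compound 3 is a number 6.2 percentage points lower from compound 1 to compound 3 (within the scatter), so no ordering between them can be claimed. The step from compound 2 to compound 3 is a number 9.5 percentage points lower from compound 2 to compound 3 (within the scatter), and the step from compound 1 to compound 2 is a number 3.3 percentage points higher from compound 1 to compound 2 (within the scatter); all three groups on the carbonyl carbon sit in the same band.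

Compound 4, `Cc1cccc(Cn2c(CN3CCN(C(=O)c4ccc(Br)cc4)CC3)nc3ccccc32)c1`, is not yet measured. The change from compound 3 reads (4-bromophenyl in place of thiophen-2-yl on a carbonyl carbon). Among the measured compounds shown here, the closest precedent is compound 1, which carries 4-ethylphenyl at the same carbonyl carbon, and the step from compound 1 to compound 3 was within the scatter, as were both other steps. Nothing among the three measured compounds suggests that swapping one aromatic group for another at this carbonyl carbon moves the number beyond the scatter, so the step expected from compound 3 to compound 4 is a number 4.2 percentage points higher from compound 3 to compound 4 (within the scatter), essentially none.

Compound 4 is therefore estimated at 65% in this assay, with a range from 50% to 80%.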

Compound 4, a percentage reported as inhibition, at one concentration (the size of the read-out at that concentration, not a potency): 25.8%
For compound 4 the middle estimate is 39.2 percentage points above the measured one; measured number below the stated range.
By their numbers in this assay, from the lowest: compound 4; then compounds 3, 1 and 2 (each within the scatter of the next).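

In this assay, the group on the carbonyl carbon turns out to matter at this position: methyl, thiophen-2-yl and 4-ethylphenyl had all stayed within the scatter of one another, yet 4-bromophenyl in place of thiophen-2-yl gives a number 35 percentage points lower from compound 3 to compound 4 (beyond the scatter), and 4-bromophenyl in place of methyl gives a number 44.5 percentage points lower from compound 2 to compound 4 (beyond the scatter). Bromo in place of ethyl on an aromatic carbon gives a number 41.2 percentage points lower from compound 1 to compound 4 (beyond the scatter), so an aromatic ring at the carbonyl carbon does not by itself bring the number down, since the 4-ethylphenyl group has one too, and the large step comes with the exchange of that single substituent. No measurement is available that would explain the size of this step.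

On these data alone, it remains open whether the step belongs to bromine in particular or would also appear with 4-chlorophenyl, 4-fluorophenyl or 4-methoxyphenyl on the same carbonyl carbon. As far as these compounds go, it is also open whether plain phenyl, with no substituent on the ring, would fall with the 4-ethylphenyl group or with the 4-bromophenyl group.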